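The source may hold more compounds than are shown below. What is called first, only, known or untested is meant among the compounds shown, and "the series" means these compounds.

Working notes on a series built on the shared core of compound 1 `Cc1cc(SC(C)C)c(S(C)(=O)=O)cc1C(=O)N=C(N)N`, varied at one aromatic carbon. In a functional assay for inhibition of sodium/hydrogen exchanger (Oryctolagus cuniculus) (a higher number here means a weaker inhibitor, a lower number a stronger inhibitor), compound 1 gives 12 nM. Compound 2 `Cc1cc(Sc2ccncc2)c(S(C)(=O)=O)cc1C(=O)N=C(N)N` gives 13 nM in this assay, and compound 3 `Cc1cc(OCc2ccccc2)c(S(C)(=O)=O)cc1C(=O)N=C(N)N` gives 28 nM. Compound 3 carries the highest number of the three, set apart from both others by steps beyond the scatter: a 2.3-fold higher number from compound 1 to compound 3 (0.37 log units; beyond the scatter) and a 2.2-fold higher number from compound 2 to compound 3 (0.33 log units; beyond the scatter), whereas a 1.1-fold higher number from compound 1 to compound 2 (0.03 log units; within the scatter).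

Compound 4 `Cc1cc(Oc2ccccc2)c(S(C)(=O)=O)cc1C(=O)N=C(N)N` differs from compound 3 by phenyl in place of benzyl on an oxygen on an aromatic ring. Within the data shown here, no measured step exchanges a benzyloxy group for a phenoxy group, so the bearing of the earlier steps is indirect: the changes leading to compound 3 swap whole substituents at this aromatic carbon and stay modest in size, which suggests the position accepts varied groups with limited effect in this assay. A step close to the scatter, in either direction, is therefore expected, a 1.1-fold lower number from compound 3 to compound 4 (0.05 log units; within the scatter). Compound 4 is estimated at 25 nM in this assay, with a range from 10 nM to 60 nM.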

Compound 4, half-maximal inhibitory concentration: 10 nM
Estimate against measurement, compound 4: 2.5-fold (0.40 log units) above; the range from low to high includes it.
By their numbers in this assay, from the lowest: compounds 4, 1 and 2 (each within the scatter of the next); then compound 3.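

In this assay, phenyl in place of benzyl on the oxygen gives a step beyond the scatter (a 2.8-fold lower number from compound 3 to compound 4 (0.45 log units; beyond the scatter)), so an oxygen on this aromatic carbon does not by itself set a higher number. Phenoxy stays within the scatter of both isopropylsulfanyl (a 1.2-fold lower number from compound 1 to compound 4 (0.08 log units; within the scatter)) and (pyridin-4-yl)sulfanyl (a 1.3-fold lower number from compound 2 to compound 4 (0.11 log units; within the scatter)), while the position still separates a change as small as benzyl to phenyl. Nothing available explains why benzyloxy stands apart from the other three groups.

From the compounds shown here alone, whether phenylsulfanyl would match phenoxy, and whether a longer chain on the oxygen, such as phenethyl, would read like benzyl, remains open. Also open, going by these compounds, is how an amine or a carboxylic acid on the phenyl ring of compound 4 would read in this assay.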